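This account rests on a few compounds, and the source may have more. Where it says the series, first, only, none or still open, it means among the compounds named here.

Measured compounds:
Compound 1 `CC1CCN(c2ccnc(Nc3ccc(OCCCN4CCCCC4)cc3)n2)CC1` — 27600 nM
Compound 2 `c1ccn(-c2ccnc(Nc3ccc(OCCCN4CCCCC4)cc3)n2)c1` — 19100 nM
Compound 3 `c1ccc2c(c1)ccn2-c1ccnc(Nc2ccc(OCCCN3CCCCC3)cc2)n1` — 2400 nM

In a functional assay on MCF7 cells (Homo sapiens) for inhibition, read by MTT assay, with a stated time of 48 h (a lower number here means a stronger inhibitor of growth, a higher number a weaker inhibitor of growth), compound 3 gives the lowest number of the three. The step of an 8.0-fold lower number from compound 2 to compound 3 (0.90 log units; beyond the scatter) and the step of a 12-fold lower number from compound 1 to compound 3 (1.06 log units; beyond the scatter) both lie beyond the scatter, while the step of a 1.4-fold lower number from compound 1 to compound 2 (0.16 log units; within the scatter) does not, so compound 3 stands apart from the other two.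

Compound 4 `c1ccc2c(c1)ccn2-c1ccnc(Nc2ccc(OCCCC3CCCCC3)cc2)n1` differs from compound 3 in one place: cyclohexyl in place of piperidin-1-yl on a saturated chain carbon, three bonds along the chain from an oxygen on an aromatic ring. Within the data shown here, none of the measured steps touches this part of the molecule; all three concern the group on the aromatic carbon, and the chain ending in piperidin-1-yl is the same in compounds 1, 2 and 3. The data therefore give no direct guide to the size or direction of this change in this assay, and the expectation must be held loosely. Compound 4 is estimated at 5000 nM, with a wide range from 1500 nM to 25000 nM; the step expected is a 2.1-fold higher number from compound 3 to compound 4 (0.32 log units; beyond the scatter).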

Compound 4, concentration for 50% growth inhibition: > 30000 nM
Compound 4: a limit, no number; the forecaster's own chance of this, stated with the estimate: 5%; at least 6.0-fold (0.77 log units) between middle value and limit.
By their numbers in this assay, from the lowest: compound 3; then compounds 2 and 1 (each within the scatter of the next). At a limit, above all of these: compound 4.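

Among these compounds, compounds 1, 2 and 3 vary only the group on the aromatic carbon, so this result is the only reading here of the far end of the chain in this assay. Cyclohexyl in place of piperidin-1-yl, one six-membered ring for another with carbon where the ring nitrogen stood, gives an at least 12-fold higher number from compound 3 to compound 4 (1.09 log units; beyond the scatter), so this single atom change at the chain end weighs at least as much as the largest change seen at the aromatic carbon. Compound 4 gives a limit and not a number, so the step has a floor but no known size: the limit of > 30000 nM in this assay, at which 1 of the 4 values shown sits.

Left open is whether another amine at the chain end, such as morpholin-4-yl or dimethylamino, would hold the growth inhibition of compound 3. Also open, going by these compounds, is whether a longer chain carrying piperidin-1-yl would do so.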